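The source may report more compounds than this note shows. Statements on the series, on what has been measured and on what is new or still open speak of the compounds shown alone.

Measured so far in a functional assay, read by fluorescence and spectrophotometry, with a stated time of 1 h; on this read-out lower numbers stand for an effect already at smaller amounts and higher numbers for an effect only at larger amounts of compound:
- compound 1 `O=S(=O)(/C=C/c1ccc(O)c(O)c1)CC1CC1`: 10500 nM
- compound 2 `O=S(=O)(/C=C/c1ccc(O)c(O)c1)CCCCCCCO`: 5900 nM

Compound 2 has only compound 1 to be compared with. Their two values lie within the usual scatter of each other, so neither can be ranked above the other.

The next compound to consider is compound 3 `CCCCCCCS(=O)(=O)/C=C/c1ccc(O)c(O)c1`, which keeps the core of compound 2 and differs from it in one place: hydrogen in place of hydroxy on a saturated chain carbon, seven bonds along the chain from a sulfonyl sulfur. In words, hydrogen takes the place of hydroxy on a saturated chain carbon, seven bonds along the chain from a sulfonyl sulfur.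

Within the data shown here, no measured pair shows the loss of a hydroxy on its own. Among the measured compounds shown here, the one measured step, a 1.8-fold lower number from compound 1 to compound 2 (0.25 log units; within the scatter), is a different exchange on the chain. It stayed within the scatter, so it offers only weak guidance and gives no reason to expect a large shift. No change beyond the scatter is therefore expected in this assay, and the expected step is a 1.2-fold lower number from compound 2 to compound 3 (0.07 log units; within the scatter). For compound 3 the estimated value is 5000 nM, with an expected range from 2000 nM to 12000 nM.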

Compound 3, half-maximal effective concentration: 7100 nM
Beside the measured number, compound 3's estimate is 1.4-fold (0.15 log units) below it; low and high end bracket the measured number.
By their numbers in this assay, from the lowest: compounds 2, 3 and 1 (each within the scatter of the next).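

In this assay, putting hydrogen in place of hydroxy on a saturated chain carbon, seven bonds along the chain from a sulfonyl sulfur, gives a 1.2-fold higher number from compound 2 to compound 3 (0.08 log units; within the scatter), so at this position the data cannot tell the hydroxy compound from the one without it. Exchanging cyclopropyl for hexyl gives a 1.5-fold lower number from compound 1 to compound 3 (0.17 log units; within the scatter), which also stays within the scatter, so with or without the hydroxy, the long chain cannot be separated from cyclopropyl in this assay, and all three compounds remain unranked. No measurement shown here speaks to what lies behind these numbers.

As far as these compounds go, it remains open whether another group at the same place on the chain, such as an amine or a carboxylic acid, would shift the number beyond the scatter, which neither hydroxy nor hydrogen does here. It is equally open whether a longer chain, or a change to the shared core of these compounds rather than to the chain, would separate any compound from the others.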